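Three Aryl Amides on a Shared Core, and a Fourth

The source may hold more compounds than are shown below. What is called first, only, known or untested is meant among the compounds shown, and "the series" means these compounds.

compound 1 `NC(=O)c1ccc(C(=O)NCCCN2CCN(CCCNc3ccnc4cc(Cl)ccc34)CC2)cc1` — "not determined" (no result reported)
compound 2 `O=C(NCCCN1CCN(CCCNc2ccnc3cc(Cl)ccc23)CC1)c1ccc(F)c(F)c1` — 10000 nM
compound 3 `CCOc1ccc(C(=O)NCCCN2CCN(CCCNc3ccnc4cc(Cl)ccc34)CC2)cc1` — 5300 nM

The three measured compounds share the core of compound 1 and differ only in the aryl group attached to the carbonyl carbon. In an ADME assay on L6 cells (Rattus norvegicus) for cytotoxicity (a higher number here means a weaker inhibitor, a lower number a stronger inhibitor), compound 1 gives "not determined" (no result reported), so it stands nowhere on the numbers shown. Compound 2 gives 10000 nM in this assay, and compound 3 gives 5300 nM. Among the compounds with values here, the single measured step, a 1.9-fold lower number from compound 2 to compound 3 (0.28 log units; within the scatter), shows how little the two measured aryl groups move the half-maximal inhibitory concentration. Compound 4 `O=C(NCCCN1CCN(CCCNc2ccnc3cc(Cl)ccc23)CC1)c1cc(F)cc(F)c1` is reached from compound 1 by 3,5-difluorophenyl in place of 4-carbamoylphenyl on a carbonyl carbon. Within the data shown here, no measured step bears on this change directly; the nearest comparison, compound 2 against compound 3, lies within the scatter, so in this assay a step of no more than the scatter is expected, in no particular direction. Compound 4 is therefore estimated to give about 9000 nM, within 4000 nM to 25000 nM.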

Compound 4, half-maximal inhibitory concentration: 11600 nM
Compound 4: the middle estimate sits 1.3-fold (0.11 log units) below what was measured; the measured number falls inside the stated range.
By their numbers in this assay, from the lowest: compounds 3, 2 and 4 (each within the scatter of the next, the first and the last beyond it).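

In this assay, the step of a 1.2-fold higher number from compound 2 to compound 4 (0.06 log units; within the scatter) shows that 3,5-difluorophenyl and 3,4-difluorophenyl on this carbonyl carbon cannot be told apart. Within the data shown here, the step of a 2.2-fold higher number from compound 3 to compound 4 (0.34 log units; beyond the scatter) is the first at this position to pass the scatter, though only modestly, so the choice of aryl group can register here. Nothing among the data shown explains that step. As far as these compounds go, what a carboxylic acid or an amine on this aryl ring would do to the number remains open. So does whether a methoxy group would read like the 4-ethoxyphenyl of compound 3.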